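Replacing the Aryl Group on the Amide Carbonyl of Compound 2

A few compounds are considered here, and "the series" means these few. Any claim that something is new, unique, unknown or untested is made for them only; others in the source may bear on it.

Compound 1, `COc1ccc(Cl)cc1C(=O)NCCC1CCN(S(=O)(=O)NC(=O)NC[C@@H]2C[C@@H]3CC[C@@H]2O3)CC1`: in a functional assay on the whole organism (blood) with Rattus norvegicus as the target, with stated times of 24 h and 1 h, at a dose of 5 mg/kg by the intraperitoneal route (a higher number here means a stronger effect of the compound at the dose given, a lower number a weaker effect), compound 1 gives 30%.
Compound 2, `Cc1ncsc1C(=O)NCCC1CCN(S(=O)(=O)NC(=O)NC[C@@H]2C[C@@H]3C=C[C@@H]2C3)CC1`: in this assay compound 2 gives 11%.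
Compound 3, `Cc1ncccc1C(=O)NCCC1CCN(S(=O)(=O)NC(=O)NC2CCCCC2)CC1`: in this assay compound 3 gives 16%.

Of the three numbers in this assay, compound 2 has the lowest. Compound 3 lies within the usual scatter of compound 2, so the two cannot be ordered. Compound 1 lies beyond the scatter above compound 2; as compound 1 and compound 2 differ in more than one place, this gap is not tied to any single change.

Compound 4, `O=C(NC[C@@H]1C[C@@H]2C=C[C@@H]1C2)NS(=O)(=O)N1CCC(CCNC(=O)c2cc(Cl)ccn2)CC1`, differs from compound 2 in one place: 4-chloropyridin-2-yl in place of 4-methyl-1,3-thiazol-5-yl on a carbonyl carbon. Going by the values given here, no pair of measured compounds shows this change on its own, so nothing in the data sets its size or direction. The author therefore expects a step from compound 2 to compound 4 of no size beyond the scatter, with the result for compound 4 estimated around 15%, between 3% and 32%. This expected step, a number 4 percentage points higher from compound 2 to compound 4 (within the scatter), stays within the scatter of compound 2.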

Compound 4, a percentage reported as activity, at one dose (the size of the read-out at that dose, not a potency): 32%
The estimate for compound 4 lay 17 percentage points below the measured number, and the stated range covers the measured number.
By their numbers in this assay, from the lowest: compounds 2 and 3 (each within the scatter of the next); then compounds 1 and 4 (each within the scatter of the next).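

In this assay, the group on this carbonyl carbon matters: 4-chloropyridin-2-yl in place of 4-methyl-1,3-thiazol-5-yl gives a number 21 percentage points higher from compound 2 to compound 4 (beyond the scatter). Unlike the gap between compound 1 and compound 2, which spans more than one place, this step is tied to a single change, with the rest of compound 2 held constant. The data shown offer no measurement that explains the step.

This one change replaces a five-membered aromatic ring with a six-membered one and also brings in the chlorine, and the compounds shown do not separate these parts. Still open, going by these compounds, is whether a plain pyridin-2-yl, without the chlorine, or a phenyl group on the same carbonyl carbon would give a number nearer compound 2 or compound 4.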